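Selenophosphate series: methoxy in place of methyl

The compounds below may be only part of what the source reports. "The series", "measured", "known", "first", "only" and "open" are said of these compounds alone.

Compound 1 `COP(=O)(OC)[Se]c1ccccc1` and compound 2 `COP(=O)(OC)[Se]c1ccc(C)cc1` share the same core and differ only by a methyl in place of hydrogen on an aromatic carbon. In a functional assay, tested at 50 uM (a lower number here means a weaker effect, a higher number a stronger effect of the compound at the concentration tested), compound 1 gives 10.4% and compound 2 gives 12.5%. Compound 2 stands highest of the two numbers, but its nearest neighbour, compound 1, lies within the scatter of it, so the two cannot be ordered. For the measured compounds named here, the step of a number 2.1 percentage points higher from compound 1 to compound 2 (within the scatter) is the only measured step so far.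

Compound 3 `COc1ccc([Se]P(=O)(OC)OC)cc1` is not yet measured. It differs from compound 2 by methoxy in place of methyl on an aromatic carbon. Going by the values given here, the one step that bears on it, a number 2.1 percentage points higher from compound 1 to compound 2 (within the scatter), concerns the same aromatic carbon and stayed within the scatter; no other step touches a methoxy. For compound 3 a step of a number 0.5 percentage points higher from compound 2 to compound 3 (within the scatter) is therefore expected, that is, none beyond the scatter. Compound 3 is estimated in this assay at 13%, with a range from 4% to 24%.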

Compound 3, a percentage reported as activity, at one concentration (the size of the read-out at that concentration, not a potency): 8.6%
Beside the measured number, compound 3's estimate is 4.4 percentage points above it; measured number inside the range.
By their numbers in this assay, from the lowest: compounds 3, 1 and 2 (each within the scatter of the next).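

In this assay, the aromatic carbon para to a group of 7 heavy atoms now carries methoxy as well as hydrogen and methyl: methoxy in place of methyl gives a number 3.9 percentage points lower from compound 2 to compound 3 (within the scatter) and methoxy in place of hydrogen gives a number 1.8 percentage points lower from compound 1 to compound 3 (within the scatter) on the same core. Both steps stay within the scatter, so compounds 1, 2 and 3 cannot be ordered, and neither methyl nor methoxy, with its one hydrogen-bond acceptor, separates from hydrogen at this carbon. Nothing on hand explains the three numbers.

Still open, going by these compounds, is whether any group at this carbon can move the number beyond the scatter, for example an amine, a carboxylic acid or a longer chain such as butoxy. The compounds shown also leave open whether this flat reading holds at other carbons of the aromatic ring.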